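Swapping an aryl amide for a hydroxyethyl amide

The source may report more compounds than this note shows. Statements on the series, on what has been measured and on what is new or still open speak of the compounds shown alone.

Of the compounds shown here, three sharing one core have been measured in an in vitro assay on FRT cells for binding affinity to Cystic fibrosis transmembrane conductance regulator (Homo sapiens), read by fluorescence, with a stated time of 20 h; on this read-out lower numbers stand for an effect already at smaller amounts and higher numbers for an effect only at larger amounts of compound. Compound 1 `COc1ccc(NC(=O)c2cc(-c3sc(NC(=O)C(C)(C)C)nc3C)n(-c3ccc(Br)cc3)n2)cc1` gives 3400 nM, compound 2 `C=CCn1nc(C(=O)Nc2ccc(OC)cc2)cc1-c1sc(NC(=O)C(C)(C)C)nc1C` gives 930 nM, and compound 3 `COc1ccc(NC(=O)c2cc(-c3sc(NC(=O)C(C)(C)C)nc3C)n(Cc3cc(Cl)ccc3OC)n2)cc1` gives 1000 nM. Compound 3 therefore holds the second highest of the three numbers; its nearest neighbour is compound 2, with a 1.1-fold higher number from compound 2 to compound 3 (0.03 log units; within the scatter), while its furthest is compound 1, with a 3.4-fold lower number from compound 1 to compound 3 (0.53 log units; beyond the scatter). The other measured step, a 3.7-fold lower number from compound 1 to compound 2 (0.56 log units; beyond the scatter), likewise concerns only the group on the aromatic nitrogen.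

Compound 4 `COc1ccc(Cl)cc1Cn1nc(C(=O)NCCO)cc1-c1sc(NC(=O)C(C)(C)C)nc1C` differs from compound 3 elsewhere: 2-hydroxyethyl in place of 4-methoxyphenyl on an amide-type nitrogen. Among the compounds with values here, none of the three measured steps touches this amide nitrogen, so there is no direct precedent for the size or direction of the change, and the expectation must be wide. Given that the measured variations at the aromatic nitrogen spanned only modest steps, the estimate for compound 4 is placed close to compound 3, as a 3.0-fold higher number from compound 3 to compound 4 (0.48 log units; beyond the scatter), but with a broad range that allows for a clear loss. Compound 4 is expected to give about 3000 nM in this assay, within a range from 600 nM to 15000 nM.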

Compound 4, half-maximal effective concentration: 3000 nM
Compound 4: the middle estimate sits on the measured number at the digits printed; measured number inside the range.
By their numbers in this assay, from the lowest: compounds 2 and 3 (each within the scatter of the next); then compounds 4 and 1 (each within the scatter of the next).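

Within the data shown here, at the amide-type nitrogen, the only change here, replacing 4-methoxyphenyl with 2-hydroxyethyl in this assay gives a 3.0-fold higher number from compound 3 to compound 4 (0.48 log units; beyond the scatter), a modest but real step at a position that none of the earlier comparisons touched. The aromatic ring at this nitrogen is therefore not required for a measurable effect, since compound 4 , which has no ring there, still gives 3000 nM, although the number does rise beyond the scatter. No measurement shown here accounts for this rise.

From the compounds shown here alone, the swap removes a six-membered aromatic ring, reduces the group from 8 heavy atoms to 3 and adds 1 hydrogen-bond donor, all in a single step, so the share of each in the change stays open. Going by these compounds, a plain ethyl group would separate the hydroxyl from the chain, while a longer chain ending in a hydroxyl, an amine or a carboxylic acid at the same nitrogen would show how the number responds to other groups, and it also remains open whether the step would be the same with allyl rather than 5-chloro-2-methoxybenzyl on the aromatic nitrogen.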